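Exchanging the benzyl group of compound 3 for furan-2-ylmethyl

A few compounds are considered here, and "the series" means these few. Any claim that something is new, unique, unknown or untested is made for them only; others in the source may bear on it.

Compound 1 `Cc1ccccc1Nc1nc(Nc2cccnc2)ncc1Cl` gives 38600 nM
Compound 2 `Cc1ccc(Nc2ncc(Cl)c(Nc3ccccc3C)n2)cc1` gives > 100000 nM as a limit of the assay, not a number
Compound 3 `CN1CCN(c2ccc(Nc3ncc(Cl)c(NCc4ccc(C(F)(F)F)cc4)n3)nc2)CC1` gives 7960 nM
Compound 4 `CN1CCN(c2ccc(Nc3ncc(Cl)c(NCc4ccco4)n3)nc2)CC1` has not yet been measured

These results come from a functional assay on Jurkat cells (Homo sapiens) for inhibition, read by CCK-8 assay, with a stated time of 48 h (a lower number here means a stronger inhibitor of growth, a higher number a weaker inhibitor of growth), and form a very small set. Compound 3, at 7960 nM, has the lower of the two values that are actual numbers, and its distance from compound 1 at 38600 nM lies beyond the scatter.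

From compound 3 to compound 4 the change is furan-2-yl in place of 4-(trifluoromethyl)phenyl on a saturated chain carbon bound to a nitrogen on an aromatic ring and it sits on a saturated chain carbon bound to a nitrogen on an aromatic ring, where furan-2-yl stands in place of 4-(trifluoromethyl)phenyl.

Among the compounds with values here, no measured step covers this place. Within the data shown here, the only measured step is an at least 2.5-fold higher number from compound 1 to compound 2 (0.41 log units; beyond the scatter) and it concerns a different exchange, 4-methylphenyl in place of pyridin-3-yl on a nitrogen on an aromatic ring. Among the measured compounds shown here, it shows only that swapping one aromatic group for another can move the number in this assay beyond the scatter, so it bears on the new change loosely and sets neither its size nor its direction. A modest rise is therefore expected, with low confidence, and the expected change is a 1.8-fold higher number from compound 3 to compound 4 (0.25 log units; within the scatter) in this estimate. For compound 4 an estimated 14000 nM is expected, in a range running from 4000 nM to 50000 nM around that figure.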

Compound 4, concentration for 50% growth inhibition: > 100000 nM
Compound 4: a limit, no number (the forecaster's own chance of this, stated with the estimate: 8%); middle value at least 7.1-fold (0.85 log units) away from the limit.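

In this assay, the group on a saturated chain carbon bound to a nitrogen on an aromatic ring turns out to matter strongly: furan-2-yl in place of 4-(trifluoromethyl)phenyl gives an at least 12-fold higher number from compound 3 to compound 4 (1.09 log units; beyond the scatter). Compound 4 gives > 100000 nM, which is a limit of the assay and not a number. Within the data shown here, the one earlier step concerned a different exchange, on a nitrogen on an aromatic ring, so this is the first sign that this place can carry growth inhibition away, and the full size of the step stays unknown because compound 4 stands at the edge of what the assay reports: the limit of > 100000 nM in this assay, at which 2 of the 4 values shown sit.

The compounds shown cannot separate the loss of the trifluoromethyl group from the change to a five-membered ring or the entry of its oxygen. They also leave open how a plain benzyl group, a thiophen-2-ylmethyl group or a longer chain such as 2-phenylethyl would stand at this place.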